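A few compounds are considered here, and "the series" means these few. Any claim that something is new, unique, unknown or untested is made for them only; others in the source may bear on it.

Among the compounds with values here, compound 1 `COc1ccc(-c2cs/c(=N/NC(=O)CSc3nnnn3-c3ccccc3)n2-c2ccccc2)cc1` is the only measured compound that gives a number: in an ADME assay on NIH3T3 cells (Mus musculus) for cytotoxicity, read by MTT assay, with a stated time of 24 h (on this read-out lower numbers stand for stronger inhibition and higher numbers for weaker inhibition), compound 1 gives 11.7 ug/mL. Compound 2 `Cc1ccc(-c2cs/c(=N/NC(=O)CSc3nnnn3-c3ccccc3)n2-c2ccccc2)cc1` carries methyl in place of methoxy on an aromatic carbon, and in this assay compound 2 reaches > 500 ug/mL, which is a limit of the assay and not a number. That is the limit of > 500 ug/mL in this assay, at which 1 of the 2 values shown sits. The step is an at least 42-fold higher number from compound 1 to compound 2 (1.63 log units; beyond the scatter). Compound 3 `COc1ccc(-c2cs/c(=N/NC(=O)CSc3nncn3C)n2-c2ccccc2)cc1` differs from compound 1 elsewhere: 4-methyl-4H-1,2,4-triazol-3-yl in place of 1-phenyl-1H-tetrazol-5-yl on a sulfur. Within the data shown here, no measured step touches this change, so neither its direction nor its size can be read from the data. Compound 3 is therefore expected to give roughly 40 ug/mL, within 8 ug/mL to 500 ug/mL. That expectation means a 3.4-fold higher number from compound 1 to compound 3 (0.53 log units; beyond the scatter).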

Compound 3, half-maximal inhibitory concentration: 167 ug/mL
Compound 3: the middle estimate sits 4.2-fold (0.62 log units) below what was measured; the measured number falls inside the stated range.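

In this assay the change on the sulfur gives a 14-fold higher number from compound 1 to compound 3 (1.15 log units; beyond the scatter) and so counts as a large step, which shows that the read-out responds to this end of compound 1 as well as to the methoxy group. Unlike the step to compound 2, this step ends on a real number, so its size is known and not just bounded. Within the data shown here, only one value remains a limit of the assay: the limit of > 500 ug/mL in this assay, at which 1 of the 3 values shown sits.

The change replaces the ring and its phenyl or methyl group together, so the data cannot say which part carries the step. A 1-methyl-1H-tetrazol-5-yl on the sulfur would separate the two.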